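The compounds below may be only part of what the source reports. "The series", "measured", "known", "first", "only" and "open" are said of these compounds alone.

Compound 1 `CC(C)(C)c1cc(OC(=O)c2ccc(Cl)cc2Cl)ccc1O`: 0.167 h
Compound 2 `CC(C)(C)c1cc(OC(=O)c2ccc(Cl)cc2)ccc1O`: < 0.25 h

In an ADME assay on a cell-free system (serum) for metabolic stability (a lower number here means that the compound disappears faster, a higher number that the compound lasts longer), compound 2 gives < 0.25 h, which is a limit and not a number. Compound 3 `Cc1ccccc1C(=O)Oc1ccc(O)c(C(C)(C)C)c1` carries the change 2-methylphenyl in place of 4-chlorophenyl on a carbonyl carbon. Among the compounds with values here, the one measured step, a step that the limit leaves unreadable from compound 1 to compound 2, is a different change, and its size cannot be read. Compound 2 sits at the limit of < 0.25 h in this assay, at which 1 of the 2 values shown sits. Within the data shown here, compound 1 gives 0.167 h, the only readable number, so a short half-life is expected to persist. The expected step, a step that the limit leaves unreadable from compound 2 to compound 3, is none beyond the scatter. Compound 3 is estimated at 0.2 h, with an expected range of 0.08 h to 0.5 h.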

Compound 3, half-life: < 0.25 h
Compound 3: only a limit was reported; the forecaster's own chance of this, stated with the estimate: 45%; the middle value does not contradict the limit.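

The step between compound 2 and compound 3 in this assay cannot be read, because both sit at a limit: the limit of < 0.25 h in this assay, at which 2 of the 3 values shown sit.

The compounds shown leave open what either half-life actually is, and whether 2-methylphenyl in place of 4-chlorophenyl changes it at all.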